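The source may hold more compounds than are shown below. What is called first, only, known or untested is meant among the compounds shown, and "the series" means these compounds.

Compound 1 `O=S(=O)(Cc1ccccc1)N1CCC2(CC1)OOC1(CCCCC1)OO2` carries a benzyl on its sulfonyl sulfur, and compound 3 `Cc1ccc(S(=O)(=O)N2CCC3(CC2)OOC2(CCCCC2)OO3)cc1` carries a 4-methylphenyl at that position instead; compound 2 `O=S(=O)(Cc1ccccc1)N1CCC2(CC1)OOC1(CCCCCC1)OO2` shares the benzyl sulfonamide of compound 1 but sits on a core whose difference from that of compound 1 is not broken down here. All three were tested in a functional assay on Huh-7 cells (Homo sapiens) for cytotoxicity, read by MTT assay, with a stated time of 72 h; on this read-out higher numbers stand for lower toxicity in this test and lower numbers for higher toxicity in this test. In this assay compound 1 reaches only a limit, > 100 ug/mL. For compound 2 the result in this assay is likewise a limit, > 100 ug/mL. Compound 3 also stops at a limit in this assay, > 100 ug/mL. The change from compound 1 to compound 3, (4-methylphenyl in place of benzyl on a sulfonyl sulfur), therefore produces a step that the two limits leave unreadable from compound 1 to compound 3, whose size the two limits leave unreadable. Compound 4 `Cc1ccc(S(=O)(=O)N2CCC3(CC2)OOC2(CCCCCC2)OO3)cc1`, not yet measured, arises from compound 2 by the same change, (4-methylphenyl in place of benzyl on a sulfonyl sulfur), made at the same place. Because (the limit of > 100 ug/mL in this assay, at which 3 of the 3 values shown sit), the step that the limit leaves unreadable from compound 2 to compound 4 is expected to be as unreadable as the earlier one, with no real shift. Compound 4 is accordingly expected to give 150 ug/mL in this assay, between 60 ug/mL and 400 ug/mL, most likely again reported only as a limit.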

Compound 4, half-maximal cytotoxic concentration: > 100 ug/mL
Compound 4: no number, only a limit (the forecaster's own chance of this, stated with the estimate: 85%); the middle value lies beyond the limit too.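

Compound 4 gives only a limit in this assay, > 100 ug/mL, so no size can be read for its step from compound 2, which also gives only a limit: the limit of > 100 ug/mL in this assay, at which 4 of the 4 values shown sit. The compounds shown leave open where the actual half-maximal cytotoxic concentration of each lies, and whether 4-methylphenyl and benzyl on the sulfonyl sulfur differ at all in this assay.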